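Bromo for Trifluoromethyl on the Sulfonamide Aryl Ring

This account rests on a few compounds, and the source may have more. Where it says the series, first, only, none or still open, it means among the compounds named here.

Of the compounds shown here, three sharing one core have been measured in a functional assay on SK-MEL-28 cells (Homo sapiens) for cytotoxicity, read by MTT assay; on this read-out higher numbers stand for weaker inhibition and lower numbers for stronger inhibition. Compound 1 `O=S(=O)(NCCCNc1nccc(-c2c(-c3cccc(F)c3)nc3sccn23)n1)c1ccc(Br)cc1` gives 9400 nM, compound 2 `O=C(NCCNc1nccc(-c2c(-c3cccc(F)c3)nc3sccn23)n1)c1ccccc1` gives 17000 nM, and compound 3 `O=S(=O)(NCCNc1nccc(-c2c(-c3cccc(F)c3)nc3sccn23)n1)c1ccc(C(F)(F)F)cc1` gives 8450 nM. Within the data shown here, the one step between compounds differing in a single place, a 1.8-fold higher number from compound 1 to compound 2 (0.26 log units; within the scatter), stays within the scatter. Compound 3 shows the lowest of the three numbers, but it lies within the scatter of both compound 1 and compound 2, so no ordering can be read from it.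

Compound 4 `O=S(=O)(NCCNc1nccc(-c2c(-c3cccc(F)c3)nc3sccn23)n1)c1ccc(Br)cc1` is the next to be measured in this assay. It differs from compound 3 by bromo in place of trifluoromethyl on an aromatic carbon. No measured step touches this place: the only step shown alters the chain substituent, not the aryl ring of the sulfonamide. Compound 1 does carry the 4-bromophenyl, yet on a longer chain, and its value sits beside that of compound 3. Compound 4 is therefore expected to show a 1.0-fold higher number from compound 3 to compound 4 (0.00 log units; within the scatter), nothing beyond the scatter. The estimate for compound 4 is 8500 nM, within 4500 nM to 17000 nM.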

Compound 4, half-maximal inhibitory concentration: 13500 nM
Estimate against measurement, compound 4: 1.6-fold (0.20 log units) below, within the range that was stated.
By their numbers in this assay, from the lowest: compounds 3, 1, 4 and 2 (each within the scatter of the next).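

In this assay, among these compounds, the first step to touch the aryl ring of the sulfonamide, trifluoromethyl to bromo on an aromatic carbon, gives a 1.6-fold higher number from compound 3 to compound 4 (0.20 log units; within the scatter) and stays within the scatter, so the two groups cannot be told apart at this place. The two other new steps also stay within the scatter: with (4-bromophenyl)sulfonyl on the amine nitrogen instead of benzoyl there is a 1.3-fold lower number from compound 2 to compound 4 (0.10 log units; within the scatter) and with the change in the chain there is a 1.4-fold higher number from compound 1 to compound 4 (0.16 log units; within the scatter) and neither change can be read as having an effect on this read-out. Nothing measured here accounts for these values.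

The compounds shown leave open whether any other group on this aromatic carbon, such as a nitrile, a methoxy group or a carboxylic acid, would move the number beyond the scatter. They also leave open whether an amine on the aryl ring or a longer chain would do so.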